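The compounds below may be only part of what the source reports. "The series", "measured", "known", "first", "only" and "open" are said of these compounds alone.

In a functional assay on HeLa cells (Homo sapiens) for antiproliferative activity, read by MTT assay, with a stated time of 24 h (a higher number here means a weaker inhibitor, a lower number a stronger inhibitor), compound 1 `FC(F)(F)c1ccc(-c2nn(-c3ccccc3)cc2-c2nc3ccccc3[nH]2)cc1` gives 4670 nM, and compound 2 `O=S(=O)(c1ccc(F)cc1)n1c(-c2cn(-c3ccccc3)nc2-c2ccc(C(F)(F)F)cc2)nc2ccccc21` gives 2190 nM. Within the data shown here, compound 2 therefore holds the lower of the only two numbers available, which makes it the stronger inhibitor of this short series so far. Among the measured compounds shown here, the single measured step is a 2.1-fold lower number from compound 1 to compound 2 (0.33 log units; beyond the scatter), and it came with (4-fluorophenyl)sulfonyl in place of hydrogen on an aromatic nitrogen.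

Compound 3 `O=S(=O)(c1ccc(Br)cc1)n1c(-c2cn(-c3ccccc3)nc2-c2ccc(C(F)(F)F)cc2)nc2ccccc21` differs from compound 2 in one place: bromo in place of fluoro on an aromatic carbon. This is bromo in place of fluoro on an aromatic carbon, turning (4-fluorophenyl)sulfonyl into (4-bromophenyl)sulfonyl.

For the measured compounds named here, no measured step tests this halogen swap directly, so the evidence is indirect. Adding the entire group gave only the modest 2.1-fold lower number from compound 1 to compound 2 (0.33 log units; beyond the scatter). A swap within that group is therefore expected to produce no larger a change in this assay, and the data favour neither direction. The expected change is a 1.2-fold lower number from compound 2 to compound 3 (0.06 log units; within the scatter), which would lie within the scatter. The estimated value for compound 3 is 1900 nM, with an expected range from 900 nM to 4000 nM.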

Compound 3, half-maximal inhibitory concentration: 1860 nM
Compound 3: middle estimate off by 1.0-fold (0.01 log units), on the high side; the measured number falls inside the stated range.
By their numbers in this assay, from the lowest: compounds 3 and 2 (each within the scatter of the next); then compound 1.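

In this assay, the swap on an aromatic carbon of the sulfonyl's six-membered ring gives a 1.2-fold lower number from compound 2 to compound 3 (0.07 log units; within the scatter), so fluoro and bromo cannot be told apart at this position, and this one pair offers no sign that the choice between these two halogens matters. The gain over the compound without a sulfonyl group now has a second example, a 2.5-fold lower number from compound 1 to compound 3 (0.40 log units; beyond the scatter), so the step seen with the fluoro compound is not confined to that one halogen, although it remains modest. No measurement that could account for this outcome is available.

On these data alone, only two halogens have been compared here, both at this one place on the ring, so it remains open whether a group of a different kind there, such as an amine, a methoxy group or a carboxylic acid, would leave the number where it is or shift it well beyond the scatter. As far as these compounds go, it is equally open whether the 4-halophenyl part is needed at all, since a plain phenyl or a methyl on the sulfonyl would separate the contribution of the sulfonyl from that of the ring it carries.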